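The source may hold more compounds than are shown below. What is called first, only, known or untested is meant among the compounds shown, and "the series" means these compounds.

The series rests on one shared core; compound 1 `O=C(Nc1ccc(Oc2ccc(-c3ncc[nH]3)cc2)cc1)Nc1ccc(F)c(C(F)(F)F)c1` and compound 2 `O=C(Nc1ccc(Oc2ccc(-c3ncc[nH]3)cc2)cc1)Nc1cc(Br)cc(C(F)(F)F)c1` differ only in the aryl group on an amide-type nitrogen. Going by the values given here, in a functional assay on A549 cells (Homo sapiens) for inhibition, read by MTT assay and WST assay, with a stated time of 72 h, tested at 10 uM (on this read-out higher numbers stand for more inhibition of growth at the one concentration tested and lower numbers for less inhibition of growth), compound 1 gives 63.3%, while compound 2 gives 44.1%, the lower of the two numbers on hand; the step of a number 19.2 percentage points lower from compound 1 to compound 2 (beyond the scatter) is the only measured step in the set. Compound 3 `O=C(Nc1ccc(Oc2ccc(-c3ncc[nH]3)cc2)cc1)Nc1ccc(F)c(Cl)c1` is not yet measured. Relative to compound 2 the change is 3-chloro-4-fluorophenyl in place of 3-bromo-5-(trifluoromethyl)phenyl on an amide-type nitrogen. Among the compounds with values here, no measured step covers this exact exchange; the one that bears on it is a number 19.2 percentage points lower from compound 1 to compound 2 (beyond the scatter), a modest drop. The change toward compound 3 takes away the 3-bromo-5-(trifluoromethyl)phenyl group that accompanied that drop, so a partial recovery is expected: the estimated step is a number 10.9 percentage points higher from compound 2 to compound 3 (beyond the scatter), upward, somewhat smaller than the measured step. The estimate for compound 3 in this assay is 55%, with a range from 38% to 72%.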

Compound 3, percent growth inhibition at one concentration: 14.6%
For compound 3 the middle estimate is 40.4 percentage points above the measured one; the whole stated range lies above it.
By their numbers in this assay, from the lowest: compound 3; then compound 2; then compound 1.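

Chloro in place of trifluoromethyl on an aromatic carbon is a single exchange on the aryl group at the amide-type nitrogen, and in this assay it gives a number 48.7 percentage points lower from compound 1 to compound 3 (beyond the scatter), the largest step in the set. The 3-bromo-5-(trifluoromethyl)phenyl group, the lower of the two aryl groups known before, now stands above 3-chloro-4-fluorophenyl, with a number 29.5 percentage points lower from compound 2 to compound 3 (beyond the scatter), so both compounds carrying trifluoromethyl give higher numbers than the one without it, and none of the three goes against this. Nothing on hand explains the differences.

On these data alone, whether a methyl group, a methoxy group or a nitrile in place of the chloro would stay near compound 3 or move toward compound 1 remains open. So does whether the order of the three holds at other concentrations.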